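Replacing a carbamoyl aryl amine with a trifluoromethylphenyl carbonyl

The compounds below may be only part of what the source reports. "The series", "measured", "known", "first", "only" and "open" are said of these compounds alone.

Measured compounds:
compound 1, `O=C(Nc1cccc(-n2cc(-c3ccncc3)c(-c3cc(O)cc(Cl)c3)n2)c1)Nc1ccc(Cl)c(C(F)(F)F)c1`, 13.8% in a functional assay on RPMI-8226 cells (Homo sapiens) for inhibition, read by sulforhodamine B assay, with a stated time of 48 h, tested at 10 uM; a higher number here means a weaker effect of the compound at the concentration tested, a lower number a stronger effect
compound 2, `O=C(Nc1cccc(-n2cc(-c3ccncc3)c(-c3cc(O)cc(Cl)c3)n2)c1)Nc1ccc(Cl)c(Cl)c1`, -15.3%
compound 3, `COc1cc(Cl)cc(-c2nn(-c3cccc(NC(=O)Nc4ccc(Cl)c(Cl)c4)c3)cc2-c2ccncc2)c1`, -4.44%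

Compound 3 stands second highest of the three numbers in this assay. Its nearest neighbour is compound 2, and the step of a number 10.9 percentage points higher from compound 2 to compound 3 (beyond the scatter) is a modest rise; the gap to compound 1 is wider, compound 1 giving 13.8%.

Compound 4, `COc1cc(Cl)cc(-c2nn(-c3cccc(NC(=O)c4cccc(C(F)(F)F)c4)c3)cc2-c2ccncc2)c1`, has not yet been measured. It differs from compound 3 in one place: 3-(trifluoromethyl)phenyl in place of (3,4-dichlorophenyl)amino on a carbonyl carbon. The carbonyl carbon keeps its amide-type nitrogen on the other side.

Among the measured compounds shown here, only the step of a number 29.1 percentage points lower from compound 1 to compound 2 (beyond the scatter) bears on this change, and only in part, since there trifluoromethyl and chloro were swapped on an aromatic carbon of a group that kept its amino link to the carbonyl. That step was modest and showed that the trifluoromethyl-bearing compound 1 gave the higher number. Compound 4 carries a trifluoromethyl group and loses the amino link and its hydrogen-bond donor, so a rise in this assay beyond the scatter is expected, of about a number 29.4 percentage points higher from compound 3 to compound 4 (beyond the scatter).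

Compound 4 is therefore expected to give 25% in this assay, within a range from 0% to 55%.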

Compound 4, a percentage reported as activity, at one concentration (the size of the read-out at that concentration, not a potency): 31.5%
Compound 4: the middle estimate sits 6.5 percentage points below what was measured; low and high end bracket the measured number.
By their numbers in this assay, from the lowest: compound 2; then compound 3; then compound 1; then compound 4.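

In this assay, among the compounds shown here, the exchange on the carbonyl carbon gives a number 35.9 percentage points higher from compound 3 to compound 4 (beyond the scatter), the first large step in this set; the two earlier steps, both modest, each altered only a single substituent. This shows that the number is sensitive to the group on this carbonyl carbon, which keeps its amide-type nitrogen on the other side, and that exchanging that group can take the number well away from that of compound 3. However, the change removes the amino link and its hydrogen-bond donor and alters the ring substituents in a single step, and no accompanying measurement explains the rise or divides it between these parts.

The compounds shown leave open how much of the step belongs to the amino link and how much to the ring substituents, a question that a pairing of (3-(trifluoromethyl)phenyl)amino or 3,4-dichlorophenyl on the same carbonyl carbon could address. They also leave open how a methylene link between the carbonyl and the ring, or a hydroxyl in place of the methoxy group of compound 4, would read in this assay.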